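A few compounds are considered here, and "the series" means these few. Any claim that something is new, unique, unknown or untested is made for them only; others in the source may bear on it.

The measured compounds:
Compound 1 `O=C(O)c1ccc(C#Cc2ccc3c(c2)C=C([N+](=O)[O-])C(C(F)(F)F)O3)cc1` gives 1090 nM in a functional assay on 1321N1 cells for antagonist activity at P2Y purinoceptor 6 (Homo sapiens), read by fluorescence and calcium flux; on this read-out lower numbers stand for stronger inhibition and higher numbers for weaker inhibition.
Compound 2 `CC(=O)NCC#Cc1ccc2c(c1)C=C([N+](=O)[O-])C(C(F)(F)F)O2` gives 7670 nM in this assay.

For the measured compounds named here, compound 2 has the highest of the two numbers measured so far; its nearest neighbour is compound 1, and the two are separated by a 7.0-fold higher number from compound 1 to compound 2 (0.85 log units; beyond the scatter), a step that puts acetamidomethyl in place of 4-carboxyphenyl on the triple-bonded carbon. Compound 3 `C[Si](C)(C)C#Cc1ccc2c(c1)C=C([N+](=O)[O-])C(C(F)(F)F)O2` has not yet been measured. Relative to compound 2 it carries a group of 4 heavy atoms (3 carbon, 1 silicon; no ring) in place of a group of 5 heavy atoms (3 carbon, 1 nitrogen, 1 oxygen; no ring), on a triple-bonded carbon; the group that enters has no common name and no hydrogen-bond donors or acceptors. Going by the values given here, only one measured step touches this site, from compound 1 to compound 2, and it shows that the group on the triple-bonded carbon can shift the number by a modest amount. No measurement shows what a group of this kind does there, so the direction is open. Compound 3 is expected to stay close to compound 2. The resulting step is expected to be a 1.3-fold lower number from compound 2 to compound 3 (0.11 log units; within the scatter), within or a little beyond the scatter. The estimate for compound 3 in this assay is 6000 nM, with a range from 1500 nM to 25000 nM.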

Compound 3, half-maximal inhibitory concentration: 785 nM
For compound 3 the middle estimate is 7.6-fold (0.88 log units) above the measured one; the measured number lies below the stated range.
By their numbers in this assay, from the lowest: compounds 3 and 1 (each within the scatter of the next); then compound 2.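

The group on the triple-bonded carbon need not be large or carry a ring to give a low number in this assay: a 9.8-fold lower number from compound 2 to compound 3 (0.99 log units; beyond the scatter), and the change is a swap of acetamidomethyl for a group with no ring and with 0 hydrogen-bond donors and 0 hydrogen-bond acceptors. Set against the 4-carboxyphenyl group, this group gives a 1.4-fold lower number from compound 1 to compound 3 (0.14 log units; within the scatter), so two very different groups cannot be told apart here, and among the three compounds only compound 2, with acetamidomethyl, stands apart from the others. Nothing available explains why these groups give the numbers they do.

The compounds shown do not tell whether the carbonyl, the amide hydrogen or the chain of acetamidomethyl goes with the higher number of compound 2, and a simple amine or a longer carbon chain on the triple-bonded carbon could help separate these. They also leave open what an unsubstituted phenyl or a tert-butyl group would give there, and thus whether the carboxylic acid of compound 1 makes any difference to its number.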